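This account rests on a few compounds, and the source may have more. Where it says the series, first, only, none or still open, it means among the compounds named here.

Three compounds sharing one core were tested in an ADME assay on HepG2 cells (Homo sapiens) for cytotoxicity, read by luminescence, with a stated time of 72 h; on this read-out higher numbers stand for an effect only at larger amounts of compound and lower numbers for an effect already at smaller amounts. Compound 2 `CCOC(=O)c1c(-c2cccc(Br)c2)[nH]c2cc(OC)ccc2c1=O` gives a value that is a limit of the assay, > 21500 nM. Compound 1 `CCOC(=O)c1c(-c2cc(F)cc(OC)c2)[nH]c2cc(OC)ccc2c1=O` differs from compound 2 by 3-fluoro-5-methoxyphenyl in place of 3-bromophenyl on an aromatic carbon. In this assay compound 1 likewise gives only a limit, > 21500 nM. Compound 3 `CCOC(=O)c1c(-c2cccc(Br)c2)[nH]c2cc(OC)c(Cl)cc2c1=O` has a core that differs from that of compound 2 by chloro in place of hydrogen on an aromatic carbon. In this assay compound 3 again gives a limit, > 21500 nM. Because all three values sit at the limit of > 21500 nM in this assay, at which 3 of the 3 values shown sit, the step that the two limits leave unreadable from compound 2 to compound 1 cannot be sized, and the same holds for a step that the two limits leave unreadable from compound 2 to compound 3.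

Compound 4 `CCOC(=O)c1c(-c2cc(F)cc(OC)c2)[nH]c2cc(OC)c(Cl)cc2c1=O` has not yet been measured. It differs from compound 3 by 3-fluoro-5-methoxyphenyl in place of 3-bromophenyl on an aromatic carbon, which is the same change that turns compound 2 into compound 1, now made on the core of compound 3. For compound 4 in this assay the expected step is a step that the limit leaves unreadable from compound 3 to compound 4, resting on the fact that compound 1 and compound 2 both sit at the limit of > 21500 nM in this assay, at which 3 of the 3 values shown sit. Compound 4 is therefore expected to give about 30000 nM, most likely reported once more only as a limit, within an expected range from 15000 nM to 100000 nM.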

Compound 4, half-maximal effective concentration: > 21500 nM
Compound 4: a limit, no number; the forecaster's own chance of this, stated with the estimate: 85%; the middle value is on the limit's open side.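

Going by these compounds alone, compound 4 gives only a limit, as do compound 1 and compound 3, so neither the step to compound 4 from compound 3 nor the one from compound 1 can be read: the limit of > 21500 nM in this assay, at which 4 of the 4 values shown sit. The compounds shown leave open what real values these four compounds have in this assay, and whether either change alters them at all.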